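Bromo in Place of Chloro on a Dihydrofolate Reductase Inhibitor

The source may hold more compounds than are shown below. What is called first, only, known or untested is meant among the compounds shown, and "the series" means these compounds.

Compound 1, `CC(C)(C)c1ccc(OCCCON2C(N)=NC(N)=NC23CCSCC3)cc1`, gives 86.6% in an assay on isolated protein for inhibition of Dihydrofolate reductase (Homo sapiens), read by spectrophotometry, using NADPH, with stated times of 5 s and 6 min, tested at 50 uM; on this read-out lower numbers stand for a weaker effect and higher numbers for a stronger effect at the one concentration tested.
Compound 2, `NC1=NC2(CCOCC2)N(OCCCOc2ccccc2Cl)C(N)=N1`, gives 88.2% in this assay.
Compound 3, `NC1=NC2(CCSCC2)N(OCCCOc2cc(Cl)c(Cl)cc2Cl)C(N)=N1`, gives 94.4% in this assay.

Of the three numbers, compound 2 stands second highest. Its nearest neighbour is compound 1, whose number lies a little lower, and the gap between them sits within the usual scatter of this kind of measurement. The furthest of the three is compound 3, whose number lies somewhat higher, yet that gap too remains within the scatter, so none of the three can be called stronger or weaker than another on these data alone.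

Within the data shown here, no step between two measured compounds that differ in one place is available, so the size of the change in this assay that a single substituent swap brings cannot be read from this set.

Compound 4, `NC1=NC2(CCOCC2)N(OCCCOc2ccccc2Br)C(N)=N1`, differs from compound 2 in one place: bromo in place of chloro on an aromatic carbon. Among the measured compounds shown here, with no measured step to lean on, and the three measured numbers all lying within the scatter of one another, no shift beyond the scatter is expected in either direction. Compound 4 is therefore estimated at 88%, with a range from 78% to 96%. The step this estimate implies, a number 0.2 percentage points lower from compound 2 to compound 4 (within the scatter), is expected to fall inside the usual scatter.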

Compound 4, a percentage reported as inhibition, at one concentration (the size of the read-out at that concentration, not a potency): 85%
For compound 4 the middle estimate is 3 percentage points above the measured one; low and high end bracket the measured number.
By their numbers in this assay, from the lowest: compounds 4, 1, 2 and 3 (each within the scatter of the next).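

Bromo in place of chloro, on an aromatic carbon ortho to a large group, is the first change in one place that can be read in this assay, and it comes out as a number 3.2 percentage points lower from compound 2 to compound 4 (within the scatter). At the one concentration tested, 2-chlorophenoxy and 2-bromophenoxy therefore cannot be told apart on this core, so this position accepts either halogen without a change that rises above the scatter of the read-out. No measurement shown here speaks to why the two compounds read alike.

On these data alone, whether a methoxy group, an amine or a carboxylic acid at this same place would move the number beyond the scatter remains open, as does the effect of a longer chain between the aromatic ring and the core. As far as these compounds go, it is also open whether the same swap would read alike on the core of compound 3, and whether compound 2 and compound 4 would still match in a full potency measurement, which a read-out at one concentration cannot give.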